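A Second Look at One Amide Substituent Swap

The source may report more compounds than this note shows. Statements on the series, on what has been measured and on what is new or still open speak of the compounds shown alone.

Measured in an assay on HEK293 cells for antagonist activity at P2X purinoceptor 7 (Homo sapiens), read by fluorescence, with a stated time of 2 h; on this read-out higher numbers stand for weaker inhibition and lower numbers for stronger inhibition:
Compound 1, `O=C(NC1CC1)c1cccc(S(=O)(=O)Oc2ccc(-c3cncn3C3CCN(C(=O)c4ccc(Cl)c(C(F)(F)F)c4)CC3)cc2)c1`: 88 nM
Compound 2, `CS(=O)(=O)c1ccc(C(=O)N2CCC(n3cncc3-c3ccc(OS(=O)(=O)c4cccc(C(=O)NC5CC5)c4)cc3)CC2)cc1`: 400 nM
Compound 3, `O=C(c1ccc(Cl)c(C(F)(F)F)c1)N1CCC(c2nc3cc(OS(=O)(=O)c4cccc5cnccc45)ccc3[nH]2)CC1`: 31 nM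

Compound 1 and compound 2 share one core and differ in a single place: 4-(methylsulfonyl)phenyl in place of 4-chloro-3-(trifluoromethyl)phenyl on a carbonyl carbon. That change gave a 4.5-fold higher number from compound 1 to compound 2 (0.66 log units; beyond the scatter), so the ring bearing the methylsulfonyl group came out as the weaker inhibitor of the pair. Compound 3 is built on a different core; how its core differs from that of compound 1 is not broken down here, but in this assay compound 3 gives 31 nM, the lowest number of the three.

Compound 4, `CS(=O)(=O)c1ccc(C(=O)N2CCC(c3nc4cc(OS(=O)(=O)c5cccc6cnccc56)ccc4[nH]3)CC2)cc1`, has not been measured yet. It applies the same change to compound 3: 4-(methylsulfonyl)phenyl in place of 4-chloro-3-(trifluoromethyl)phenyl on a carbonyl carbon. The step from compound 3 to compound 4 is expected to be a 4.5-fold higher number from compound 3 to compound 4 (0.65 log units; beyond the scatter), because the same change on the other core gave a 4.5-fold higher number from compound 1 to compound 2 (0.66 log units; beyond the scatter). On that basis compound 4 is estimated at 140 nM, with a likely range from 60 nM to 350 nM.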

Compound 4, half-maximal inhibitory concentration: 7 nM
Beside the measured number, compound 4's estimate is 20-fold (1.30 log units) above it; measured number below the stated range.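

In this assay the swap to 4-(methylsulfonyl)phenyl on the core of compound 3 gave a 4.4-fold lower number from compound 3 to compound 4 (0.65 log units; beyond the scatter) and so ran opposite to the earlier step. The same change therefore did not carry over from one core to the other, even in direction: the same change on two cores in this assay, a 4.5-fold higher number (0.66 log units; beyond the scatter) from compound 1 to compound 2 and a 4.4-fold lower number (0.65 log units; beyond the scatter) from compound 3 to compound 4, 20-fold (1.30 log units) apart, beyond the scatter of two such steps.
Among these compounds, this shows that the result of the swap depends on the core it sits on, but with only two cores it gives no rule for a third and does not explain the reversal.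

Going by these compounds, it remains open which part of the difference between the two cores matters. On these data alone, it is also open whether a nitrile or a carboxylic acid in place of the methylsulfonyl group would split the two cores in the same way.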